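The source may report more compounds than this note shows. Statements on the series, on what has been measured and on what is new or still open speak of the compounds shown alone.

Three compounds sharing a pyrrole carboxylic acid scaffold were examined in an assay on cells for inhibition of Palmitoleoyl-protein carboxylesterase NOTUM variant C330S (Homo sapiens), read by fluorescence, with a stated time of 40 min; a higher number here means a weaker inhibitor, a lower number a stronger inhibitor. Compound 1 `Cc1c(C(=O)O)ccn1-c1ccccc1` gives 3800 nM, compound 2 `Cc1cc(C(=O)O)c(C)n1-c1ccc(C(F)(F)F)c(Cl)c1` gives 1500 nM, and compound 3 `Cc1cc(C(=O)O)c(C)n1-c1cccc(Cl)c1` gives 430 nM. Between compound 3 and compound 2 the change is trifluoromethyl in place of hydrogen on an aromatic carbon, and it produced a 3.5-fold higher number from compound 3 to compound 2 (0.54 log units; beyond the scatter). The difference between the core of compound 1 and the core of compound 3 is not broken down here.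

Compound 4 `Cc1c(C(=O)O)cc(C(F)(F)F)n1-c1ccccc1` is not yet measured. It differs from compound 1 by trifluoromethyl in place of hydrogen on an aromatic carbon; this is the same kind of change as that from compound 3 to compound 2, but its place is on an aromatic carbon of a five-membered aromatic ring with 1 nitrogen rather than of a six-membered aromatic ring of carbon only. Resting on the weakening seen in compound 2 relative to compound 3 a 3.5-fold higher number from compound 3 to compound 2 (0.54 log units; beyond the scatter), the expected step is a 1.8-fold higher number from compound 1 to compound 4 (0.27 log units; within the scatter), with wide uncertainty given the different ring. Compound 4 is thus estimated at 7000 nM, between 2500 nM and 25000 nM.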

Compound 4, half-maximal inhibitory concentration: 22000 nM
Estimate against measurement, compound 4: 3.1-fold (0.50 log units) below, within the range that was stated.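

Put on the five-membered aromatic ring of compound 1, trifluoromethyl in place of hydrogen gave a 5.8-fold higher number from compound 1 to compound 4 (0.76 log units; beyond the scatter) in this assay. Set beside the earlier case, the same change raised the number on both cores, by amounts that cannot be told apart: the same change on two cores in this assay, a 3.5-fold higher number (0.54 log units; beyond the scatter) from compound 3 to compound 2 and a 5.8-fold higher number (0.76 log units; beyond the scatter) from compound 1 to compound 4, 1.7-fold (0.22 log units) apart, within the scatter of two such steps. For the compounds shown here, this shows that the direction and rough size of the step carried over between these two cores, although the group sits on a different ring in each; it rests on only two pairs, however, and does not show why the number rises or whether the step would hold on any other core.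

On these data alone, whether a nitrile or an ethyl group on that same aromatic carbon would raise the number as trifluoromethyl does remains open.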